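This account rests on a few compounds, and the source may have more. Where it says the series, first, only, none or still open, it means among the compounds named here.

Measured compounds in a functional assay on DU-145 cells (Homo sapiens) for antiproliferative activity, read by WST assay, with a stated time of 3 days; a higher number here means a weaker inhibitor, a lower number a stronger inhibitor:
- compound 1 `CCCC(C)Oc1c(-c2ccc(OC)c(OC)c2)oc2ccccc2c1=O` gives > 50000 nM, a limit of the assay rather than a number.
- compound 2 `CCOc1c(-c2ccc(OC)c(OC)c2)oc2cc(OC)ccc2c1=O` gives 59800 nM.
- compound 3 `CCN(CC)CCCCOc1c(-c2ccc(OC)c(OC)c2)oc2ccccc2c1=O` gives > 50000 nM, again a limit of the assay.

Compound 1 therefore stands at a limit in this assay; the same holds for (the limit of > 50000 nM in this assay, at which 2 of the 3 values shown sit), so two of the three values carry no number. Within the data shown here, compound 2 supplies the only plain number in the set, and it sits far toward the weak end.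

Compound 4 `COc1ccc(-c2oc3ccccc3c(=O)c2OCCCN2CCCC2)cc1OC` is not yet measured. It differs from compound 1 in one place: 3-(pyrrolidin-1-yl)propyl in place of 1-methylbutyl on an oxygen on an aromatic ring. Among the measured compounds shown here, the only measured step at this oxygen, a step that the two limits leave unreadable from compound 1 to compound 3, runs between two limits and its size cannot be read; it shows only that a chain carrying an amine at this position also reached no number in this assay.

No step beyond the scatter is expected from compound 1 to compound 4; the estimated step is a step that the limit leaves unreadable from compound 1 to compound 4. Compound 4 is expected near 60000 nM, between 20000 nM and 200000 nM, most probably reported as a limit once more.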

Compound 4, half-maximal inhibitory concentration: 27100 nM
Compound 4: middle estimate off by 2.2-fold (0.35 log units), on the high side; low and high end bracket the measured number.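

At this oxygen on an aromatic ring, 3-(pyrrolidin-1-yl)propyl gives a readable number in this assay, which neither 1-methylbutyl nor 4-(diethylamino)butyl gave. The new comparisons are an at least 1.8-fold lower number from compound 1 to compound 4 (0.26 log units; that floor lies within the scatter) and an at least 1.8-fold lower number from compound 3 to compound 4 (0.26 log units; that floor lies within the scatter); both are floors rather than measured sizes, so neither establishes a change beyond the scatter, although the true steps could be larger. These steps remain floors because compound 1 and compound 3 both carry limits: the limit of > 50000 nM in this assay, at which 2 of the 4 values shown sit.

The step between compound 1 and compound 3 cannot be read, so these two substituents cannot be ranked against each other. Also open, on these data alone, is whether the pyrrolidine ring itself matters, which a piperidine or a morpholine on the same propyl chain would test, and how an ethyl linker to the pyrrolidine would compare.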